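The source may report more compounds than this note shows. Statements on the series, on what has been measured and on what is new or still open speak of the compounds shown alone.

Among the measured compounds shown here, compound 1 `O=C(O)c1ccc(Cl)cc1CC[C@@H]1CCC[C@@H]1NC(=O)C1CCN(c2ccc(C(F)(F)F)cc2)CC1` is one of two compounds measured in an ADME assay on the whole organism for pharmacokinetics, with Rattus norvegicus as the target, at a dose of 1 mg/kg by the intravenous route; a higher number here means faster removal of the compound, a lower number slower removal. In this assay compound 1 gives 16 mL/min/kg, while compound 2 `Cc1cccc2ccc(N3CCC(C(=O)N[C@H]4CCC[C@H]4CCc4ccccc4C(=O)O)CC3)nc12` gives 31 mL/min/kg; these two numbers lie within the usual scatter of one another, so neither stands apart. Compound 3 `O=C(O)c1ccc(F)cc1CC[C@@H]1CCC[C@@H]1NC(=O)C1CCN(c2ccc(C(F)(F)F)cc2)CC1` differs from compound 1 in a single place: fluoro in place of chloro on an aromatic carbon. For the measured compounds named here, no pair of measured compounds shows what this exchange does in this assay, so a step beyond the scatter is not expected in either direction. Compound 3 is therefore estimated at 18 mL/min/kg, with a range from 9 mL/min/kg to 36 mL/min/kg, the expected step being a 1.1-fold higher number from compound 1 to compound 3 (0.05 log units; within the scatter).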

Compound 3, clearance: 12 mL/min/kg
The estimate for compound 3 lay 1.5-fold (0.18 log units) above the measured number; measured number inside the range.
By their numbers in this assay, from the lowest: compounds 3, 1 and 2 (each within the scatter of the next, the first and the last beyond it).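

In this assay, the aromatic carbon para to the carboxy group now has its first direct comparison: fluoro in place of chloro gives a 1.3-fold lower number from compound 1 to compound 3 (0.12 log units; within the scatter). At this position, then, the two halogens cannot be told apart in clearance, and this one exchange offers no gain or loss beyond the scatter. Nothing measured here bears on what lies behind this result. Going by these compounds, whether a methoxy group or an amine at this place would move the number beyond the scatter stays open. Also open, on these data alone, is how the same exchange reads on other carbons of this ring.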